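This account rests on a few compounds, and the source may have more. Where it says the series, first, only, none or still open, it means among the compounds named here.

The measured compounds are:
compound 1, `COc1cc(-c2nn(-c3cccc(NC(=O)c4ccc(Cl)c(C(F)(F)F)c4)c3)cc2-c2ccncc2)ccc1Cl`, which in a functional assay on HCC 2998 cells (Homo sapiens) for inhibition, read by sulforhodamine B assay, with a stated time of 48 h (a lower number here means a stronger inhibitor of growth, a higher number a weaker inhibitor of growth), gives only the limit > 32500 nM;
compound 2, `COc1cc(-c2nn(-c3cccc(NC(=O)c4cccc(C(F)(F)F)c4)c3)cc2-c2ccncc2)ccc1Cl`, which in this assay gives 17600 nM;
compound 3, `COc1cc(-c2nn(-c3cccc(NC(=O)Nc4ccc(Cl)c(C(F)(F)F)c4)c3)cc2-c2ccncc2)ccc1Cl`, which in this assay gives 7300 nM.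

Compound 1 stands at the limit of > 32500 nM in this assay, at which 1 of the 3 values shown sits, so only a bound and no number is known for it. Compound 4, `COc1cc(-c2nn(-c3cccc(NC(=O)c4ccccc4)c3)cc2-c2ccncc2)ccc1Cl`, is not yet measured. It differs from compound 1 in one place: phenyl in place of 4-chloro-3-(trifluoromethyl)phenyl on a carbonyl carbon.

For the measured compounds named here, of the measured steps, the one from compound 1 to compound 2 bears most closely, since it also strips the same aromatic ring, though only of its chloro: an at least 1.8-fold lower number from compound 1 to compound 2 (0.26 log units; that floor lies within the scatter). The steps to compound 3 change the carbonyl substituent in another way and bear less: an at least 4.4-fold lower number from compound 1 to compound 3 (0.64 log units; beyond the scatter) and a 2.4-fold lower number from compound 2 to compound 3 (0.38 log units; beyond the scatter). Going by the values given here, compound 4 goes further than compound 2, removing the trifluoromethyl as well, and no measured pair covers that part. The change is therefore expected to move compound 4 below the bound of compound 1 by about the size seen for compound 2, or a little more, but with wide uncertainty: an at least 1.6-fold lower number from compound 1 to compound 4 (0.21 log units; that floor lies within the scatter) is the expected step. Compound 4 is estimated at 20000 nM in this assay, with a range from 8000 nM to 50000 nM.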

Compound 4, concentration for total growth inhibition: 22400 nM
For compound 4 the middle estimate is 1.1-fold (0.05 log units) below the measured one; the measured number falls inside the stated range.
By their numbers in this assay, from the lowest: compound 3; then compounds 2 and 4 (each within the scatter of the next). At a limit, above all of these: compound 1.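

In this assay, taking the trifluoromethyl off the ring of compound 2 gives a change that cannot be told apart from the scatter, a 1.3-fold higher number from compound 2 to compound 4 (0.10 log units; within the scatter), so among these amides the bare phenyl of compound 4 is not separated from the 3-(trifluoromethyl)phenyl of compound 2. For the compounds shown here, compound 3 stays clearly apart from compound 4, a 3.1-fold higher number from compound 3 to compound 4 (0.49 log units; beyond the scatter), and the earlier steps set it apart from compound 2 as well, so among the compounds with a number, only the one with the (4-chloro-3-(trifluoromethyl)phenyl)amino group on the carbonyl carbon stands out. Compound 1 gives only a limit and not a number, so its step can be read only as a floor that lies within the scatter, an at least 1.4-fold lower number from compound 1 to compound 4 (0.16 log units; that floor lies within the scatter), and the full size of this change stays unknown: the limit of > 32500 nM in this assay, at which 1 of the 4 values shown sits.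

The compounds shown leave open whether a plain phenylamino group on the carbonyl carbon would keep the lower number of compound 3 or fall in with compounds 2 and 4. They also leave open how a ring carrying a carboxylic acid or an amine in place of the phenyl would behave in this assay.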